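Indole methoxy step in a neuroblastoma cytotoxicity series

The source may report more compounds than this note shows. Statements on the series, on what has been measured and on what is new or still open speak of the compounds shown alone.

Compound 3 `O=C(CN1CCN(C(=O)c2cccc(F)c2)CC1)N1CCN(CCCc2c[nH]c3ccccc23)CC1` belongs to a set of three analogues on one core. In an ADME assay on SH-SY5Y cells (Homo sapiens) for cytotoxicity, read by MTT assay, with a stated time of 72 h (on this read-out higher numbers stand for weaker inhibition and lower numbers for stronger inhibition), compound 3 gives 165000 nM. Compound 1 `O=C(CN1CCN(C(=O)c2cccc(Cl)c2)CC1)N1CCN(CCCc2c[nH]c3ccccc23)CC1` gives 120000 nM in this assay, and the step of a 1.4-fold higher number from compound 1 to compound 3 (0.14 log units; within the scatter), so compound 3 stands together with compound 1. Compound 2 `COc1cccc(C(=O)N2CCN(CC(=O)N3CCN(CCCc4c[nH]c5ccccc45)CC3)CC2)c1` gives only a limit, > 200000 nM; (the limit of > 200000 nM in this assay, at which 1 of the 3 values shown sits). Compound 4 `COc1ccc2[nH]cc(CCCN3CCN(C(=O)CN4CCN(C(=O)c5cccc(F)c5)CC4)CC3)c2c1` differs from compound 3 by methoxy in place of hydrogen on an aromatic carbon. For the measured compounds named here, no measured step touches that position: the measured changes all sit elsewhere on the core, and each of them (an at least 1.6-fold higher number from compound 1 to compound 2 (0.22 log units; that floor lies within the scatter); an at least 1.2-fold lower number from compound 2 to compound 3 (0.08 log units; that floor lies within the scatter)) stays within the scatter or ends at a limit. Nothing therefore argues for a change beyond the scatter, and compound 4 is expected close to its parent: no change at the digits printed from compound 3 to compound 4 (within the scatter). Compound 4 is estimated at 165000 nM, with a range from 80000 nM to 200000 nM.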

Compound 4, half-maximal inhibitory concentration: > 200000 nM
Compound 4 ended at the assay's limit; the forecaster's own chance of this, stated with the estimate: 35%; middle value at least 1.2-fold (0.08 log units) away from the limit.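

The first change read at this position, 1H-indol-3-yl to 5-methoxy-1H-indol-3-yl, gives an at least 1.2-fold higher number from compound 3 to compound 4 (0.08 log units; that floor lies within the scatter) in this assay. Methoxy on this aromatic carbon therefore gives no sign of stronger inhibition, though the true size of the step cannot be read. Compound 4 gives a limit and not a number: the limit of > 200000 nM in this assay, at which 2 of the 4 values shown sit.

As far as these compounds go, whether an amine or a carboxylic acid at this position would give a step beyond the scatter remains open. So does whether methoxy here would read the same with chloro in place of fluoro on the benzoyl side.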